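Notes on the step from compound 3 to compound 4

The source may report more compounds than this note shows. Statements on the series, on what has been measured and on what is new or still open speak of the compounds shown alone.

The series shares one core, seen in compound 1 `O=C1Nc2ccc(-c3ccc(C(F)(F)F)cc3)cc2C1=O`, compound 2 `CCN1C(=O)C(=O)c2cc(-c3ccc(OC)cc3)ccc21` and compound 3 `COc1ccc(-c2ccc3c(c2)C(=O)C(=O)N3Cc2ccc(F)cc2)cc1`. In a functional assay on K562 cells (Homo sapiens) for antiproliferative activity, read by MTT assay, with a stated time of 48 h (on this read-out lower numbers stand for stronger inhibition and higher numbers for weaker inhibition), compound 1 gives only a limit, > 10000 nM. Compound 2 gives 2200 nM in this assay. For the measured compounds named here, compound 3 gives 560 nM in this assay, the lowest of the two numbers; the single measured step, a 3.9-fold lower number from compound 2 to compound 3 (0.59 log units; beyond the scatter), is the one that leads to it. Compound 4 `COc1ccc(-c2ccc3c(c2)C(=O)C(=O)N3Cc2ccccc2OC)cc1` is not yet measured; it differs from compound 3 by 2-methoxyphenyl in place of 4-fluorophenyl on a saturated chain carbon bound to an amide-type nitrogen in a ring. Going by the values given here, the measured step exchanged methyl for 4-fluorophenyl at that same place, and no measured pair compares one aromatic group with another at that place, so the step bears on the present change only in showing that an aromatic group is accepted at that place. For compound 4 a step within the scatter is expected, a 1.1-fold higher number from compound 3 to compound 4 (0.03 log units; within the scatter). The estimate for compound 4 in this assay is 600 nM, with a range from 250 nM to 1500 nM.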

Compound 4, half-maximal inhibitory concentration: 40 nM
Compound 4: the middle estimate sits 15-fold (1.18 log units) above what was measured; measured number outside the range, below it.
By their numbers in this assay, from the lowest: compound 4; then compound 3; then compound 2. At a limit, above all of these: compound 1.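

For the compounds shown here, compound 3 showed only that an aromatic group is accepted on a saturated chain carbon bound to an amide-type nitrogen in a ring; compound 4 shows that the choice of aromatic group also matters there. In this assay, the exchange of 4-fluorobenzyl for 2-methoxybenzyl gives a 14-fold lower number from compound 3 to compound 4 (1.15 log units; beyond the scatter), and the change measured from methyl gives a 55-fold lower number from compound 2 to compound 4 (1.74 log units; beyond the scatter). Nothing in the data at hand accounts for the size of these steps.

The compounds shown do not separate the exchange of fluorine for methoxy from the change in where the substituent stands, a question that 2-fluorobenzyl and 4-methoxybenzyl would address. Also open, going by these compounds, is whether the methoxy group itself is needed, or whether 2-hydroxybenzyl, 2-aminobenzyl or 2-ethoxybenzyl would give a similar number.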